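Adding a Nitrile to the Core of Compound 3

The compounds below may be only part of what the source reports. "The series", "measured", "known", "first", "only" and "open" are said of these compounds alone.

Of the compounds shown here, three have so far been measured in an assay on isolated protein for inhibition of Long-chain-fatty-acid--CoA ligase 1 (Homo sapiens), read by mass spectrometry, with a stated time of 90 min, in the presence of a further agent that is not named here; on this read-out higher numbers stand for weaker inhibition and lower numbers for stronger inhibition. Compound 1 `O=C(O)[C@H]1CC[C@@H](Oc2ccc3oc(-c4ccccc4)nc3c2)CC1` gives 4400 nM, compound 2 `Cc1cccc(Cc2nc3cc(O[C@H]4CC[C@@H](C(=O)O)CC4)ccc3o2)c1` gives 39 nM, and compound 3 `Cc1cccc(Cc2cc3cc(O[C@H]4CC[C@@H](C(=O)O)CC4)ccc3n2C)c1` gives 400 nM. Compound 3 thus holds the second highest of the three numbers: compound 2 sits well below it and compound 1 well above it, both gaps lying beyond the usual scatter. Among the compounds with values here, the only step recorded between compounds that differ in a single place is a 110-fold lower number from compound 1 to compound 2 (2.05 log units; beyond the scatter), an exchange of phenyl for 3-methylbenzyl on an aromatic carbon of the shared core.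

Compound 4 `Cc1cccc(Cc2c(C#N)c3cc(O[C@H]4CC[C@@H](C(=O)O)CC4)ccc3n2C)c1` differs from compound 3 by cyano in place of hydrogen on an aromatic carbon. Within the data shown here, no measured step concerns a cyano group, and the single recorded step involves a different group at a different place, so it offers little direct guidance here. The step from compound 1 to compound 2 was large, but it replaced a whole aromatic substituent rather than adding a small group to the core.

Compound 4 is therefore expected to show a number in this assay close to that of compound 3, with a step of a 1.3-fold lower number from compound 3 to compound 4 (0.12 log units; within the scatter) that stays within or only slightly beyond the scatter, in either direction. The estimate for compound 4 is 300 nM, with a range from 100 nM to 1200 nM.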

Compound 4, half-maximal inhibitory concentration: 1900 nM
Estimate against measurement, compound 4: 6.3-fold (0.80 log units) below; measured number outside the range, above it.
By their numbers in this assay, from the lowest: compound 2; then compound 3; then compound 4; then compound 1.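

In this assay, cyano in place of hydrogen on the aromatic carbon of the five-membered ring brings a 4.8-fold higher number from compound 3 to compound 4 (0.68 log units; beyond the scatter), a modest step beyond the scatter towards weaker inhibition. Within the data shown here, this shows that the carbon next to the ring atom that bears a 3-methylbenzyl group, two ring bonds from the ring nitrogen, does not tolerate every change without cost: a substituent of only 2 heavy atoms moves the number measurably, whereas the only earlier step, a 110-fold lower number from compound 1 to compound 2 (2.05 log units; beyond the scatter), was an exchange of a whole aromatic substituent at a different place. Nothing available here bears on why the number rises at this carbon.

The compounds shown leave open whether the rise is specific to the nitrile or would follow from any group at this carbon, such as a fluorine atom, a chlorine atom, a primary amide or a hydroxymethyl group. They also leave open whether the same exchange would give a step of similar size if a longer chain replaced the 3-methylbenzyl group or an ethyl group replaced the methyl group on the ring nitrogen.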